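Shortening the chain: from butyl to propyl

This account rests on a few compounds, and the source may have more. Where it says the series, first, only, none or still open, it means among the compounds named here.

Measured so far:
Compound 1, `Cc1cncc(OC[C@@H]2CCCN2C)c1`: 78.8%
Compound 2, `CCCCc1cncc(OC[C@@H]2CCCN2C)c1`: 8.7%

Both compounds were tested in an assay on IMR-32 cells with Neuronal acetylcholine receptor; alpha4/beta2 (Homo sapiens) as the target; a lower number here means a smaller maximal response, a higher number a larger maximal response. Compound 2 stands lowest of the two numbers, and its nearest neighbour is compound 1, with 78.8%. Within the data shown here, the only measured step runs between these two: a number 70.1 percentage points lower from compound 1 to compound 2 (beyond the scatter), a large drop that came with propyl in place of hydrogen on a saturated chain carbon bound to an aromatic carbon.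

Compound 3, `CCCc1cncc(OC[C@@H]2CCCN2C)c1`, differs from compound 2 as follows: hydrogen in place of methyl on a saturated chain carbon, three bonds along the chain from an aromatic carbon. This is a partial reversal of the measured step, taking away one carbon of the chain that was added. That step bears directly on the expectation, but it shows only the two ends, not how the response changes in between. An increase beyond the scatter is therefore expected, of uncertain size. This amounts to an expected step of a number 21.3 percentage points higher from compound 2 to compound 3 (beyond the scatter). Compound 3 is estimated to give 30%, within a range from 8% to 65%.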

Compound 3, largest response reached (reported as maximum), in percent of the reference or control that the assay uses: 2.5%
Compound 3: the middle estimate sits 27.5 percentage points above what was measured; the whole stated range lies above it.
By their numbers in this assay, from the lowest: compounds 3 and 2 (each within the scatter of the next); then compound 1.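

In this assay, taking the end carbon off the butyl chain to leave propyl gives a step of a number 6.2 percentage points lower from compound 2 to compound 3 (within the scatter) and so brings no recovery of the response. The propyl chain on its own carries nearly all of the loss, with a step of a number 76.3 percentage points lower from compound 1 to compound 3 (beyond the scatter) in which ethyl replaces hydrogen on a saturated chain carbon bound to an aromatic carbon, so the large drop does not depend on the butyl chain's last carbon. Nothing measured here explains why these longer chains give so small a maximal response.

Still open, from the compounds shown here alone, is whether an ethyl group in place of the methyl of compound 1 keeps the high response or already loses it, which would show how short the chain must be. Also open, going by these compounds, is how a pentyl chain, or a propyl chain ending in a hydroxyl group or an amine, would behave here.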